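The source may report more compounds than this note shows. Statements on the series, on what has been measured and on what is new or still open speak of the compounds shown alone.

Working notes on the series, where the shared core stays fixed and only the group on the triple-bonded carbon varies. In an in vitro ADME assay on microsomes from liver (Rattus norvegicus) for metabolic stability, tested at 2 uM (a higher number here means that the compound lasts longer, a lower number that the compound disappears faster), compound 3 `O=C(O)CC#Cc1ccc(NC(=O)CSc2nnnn2-c2ccc(C3CC3)cc2Cl)c(Cl)c1` gives 0.317 h, level within the scatter with compound 1 `O=C(O)C#Cc1ccc(NC(=O)CSc2nnnn2-c2ccc(C3CC3)cc2Cl)c(Cl)c1` at 0.333 h, while compound 2 `CC(C)(O)C#Cc1ccc(NC(=O)CSc2nnnn2-c2ccc(C3CC3)cc2Cl)c(Cl)c1` stands clear of both at 1.4 h. The next change leads to compound 4 `CC(C)(C#Cc1ccc(NC(=O)CSc2nnnn2-c2ccc(C3CC3)cc2Cl)c(Cl)c1)C(=O)NS(C)(=O)=O`: 1-methyl-1-((methylsulfonyl)carbamoyl)ethyl in place of carboxymethyl on a triple-bonded carbon. In words, this is 1-methyl-1-((methylsulfonyl)carbamoyl)ethyl in place of carboxymethyl on a triple-bonded carbon.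

Two kinds of measured step bear on it. Swapping carboxy for carboxymethyl gave a 1.1-fold lower number from compound 1 to compound 3 (0.02 log units; within the scatter). Moving from 1-hydroxy-1-methylethyl to carboxymethyl gave a 4.4-fold lower number from compound 2 to compound 3 (0.65 log units; beyond the scatter), and the reverse of this is the closest guide, as compound 2 and compound 4 both carry a 1-methyl-substituted group. The contrast between compound 1 and compound 2 repeats that size: a 4.2-fold higher number from compound 1 to compound 2 (0.62 log units; beyond the scatter). Within the data shown here, no measured compound holds the (methylsulfonyl)carbamoyl group, so a modest rise is expected in this assay, smaller than the full gap to compound 2. The expected step is a 2.5-fold higher number from compound 3 to compound 4 (0.40 log units; beyond the scatter). For compound 4 the estimated half-life is 0.8 h, with an expected range of 0.35 h to 1.8 h.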

Compound 4, half-life: 1.37 h
Compound 4: the middle estimate sits 1.7-fold (0.23 log units) below what was measured; low and high end bracket the measured number.
By their numbers in this assay, from the lowest: compounds 3 and 1 (each within the scatter of the next); then compounds 4 and 2 (each within the scatter of the next).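

In this assay, the step of a 4.3-fold higher number from compound 3 to compound 4 (0.64 log units; beyond the scatter) and the step of a 4.1-fold higher number from compound 1 to compound 4 (0.61 log units; beyond the scatter) show that the higher level at this position is not tied to the 1-hydroxy-1-methylethyl group. The step of a 1.0-fold lower number from compound 2 to compound 4 (0.01 log units; within the scatter) shows that (methylsulfonyl)carbamoyl in place of hydroxy on the same saturated chain carbon leaves the number level, so among these four compounds the two carrying a 1-methyl-substituted group stand clear of compound 1 and compound 3, with none going against this. No supporting data bear on why the number changes with this group.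

The step from compound 3 to compound 4 changes both the substitution on the chain carbon and the acid group, and the compounds shown do not separate the two; a 1-carboxy-1-methylethyl group on the same triple-bonded carbon would do so. As far as these compounds go, whether an amine or a longer chain there holds the same level also stays open.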